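Working notes: hydrogen in place of chloro in the series

The source may report more compounds than this note shows. Statements on the series, on what has been measured and on what is new or still open speak of the compounds shown alone.

Measured in an ADME assay on GES1 cells (Homo sapiens) for cytotoxicity, read by MTT assay, with a stated time of 24 h (a lower number here means that less compound is tolerated, a higher number that more compound is tolerated), so far:
compound 1 `CC1(C)[C@H]2CC[C@]1(C)N(Cc1cn(-c3ccccc3C#N)nn1)C(=O)C2` gives 9450 nM as its value
compound 2 `CC1(C)[C@H]2CC[C@]1(C)N(Cc1cn(-c3ccccc3F)nn1)C(=O)C2` gives 5160 nM as its value
compound 3 `CC1(C)[C@H]2CC[C@]1(C)N(Cc1cn(-c3ccccc3Cl)nn1)C(=O)C2` gives 5370 nM as its value

Compound 3, at 5370 nM in this assay, lies within the scatter of both other compounds. The closest comparison is a 1.0-fold higher number from compound 2 to compound 3 (0.02 log units; within the scatter), and the widest is a 1.8-fold lower number from compound 1 to compound 3 (0.25 log units; within the scatter).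

Next is compound 4 `CC1(C)[C@H]2CC[C@]1(C)N(Cc1cn(-c3ccccc3)nn1)C(=O)C2`, which has hydrogen in place of chloro on an aromatic carbon, so that 2-chlorophenyl becomes phenyl.

All three measured steps bear on this change, since each exchanges one group at that same carbon. Fluoro in place of cyano gave a 1.8-fold lower number from compound 1 to compound 2 (0.26 log units; within the scatter), and chloro in place of fluoro gave a 1.0-fold higher number from compound 2 to compound 3 (0.02 log units; within the scatter). Within the series, compound 1, compound 2 and compound 3 therefore show no step beyond the scatter. None of them has hydrogen at that carbon, so the data do not test this exact change.

No step beyond the scatter is expected, and no direction is favoured. The estimated step is a 1.1-fold higher number from compound 3 to compound 4 (0.05 log units; within the scatter) and would stay within the scatter. For compound 4 the expected value is 6000 nM, with an estimated range from 3000 nM to 11000 nM as its bounds.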

Compound 4, half-maximal cytotoxic concentration: 6690 nM
Beside the measured number, compound 4's estimate is 1.1-fold (0.05 log units) below it, and the stated range covers the measured number.
By their numbers in this assay, from the lowest: compounds 2, 3, 4 and 1 (each within the scatter of the next).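

In this assay hydrogen at this aromatic carbon can now be compared directly with the substituted compounds, and the change from 2-chlorophenyl to phenyl gives a 1.2-fold higher number from compound 3 to compound 4 (0.10 log units; within the scatter) on this one exchange. The comparisons with the other two groups read the same way, with a 1.3-fold higher number from compound 2 to compound 4 (0.11 log units; within the scatter) against fluoro and a 1.4-fold lower number from compound 1 to compound 4 (0.15 log units; within the scatter) against cyano, so no exchange among hydrogen, fluoro, chloro and cyano at this carbon leaves the scatter, and a substituent here is not required for the number to stay in this range. Nothing measured alongside these numbers offers an explanation for this flat picture.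

Going by these compounds, what an amine, a carboxylic acid or a methoxy group would do at this carbon remains open, as does whether any group placed here can move the number beyond the scatter. Also open, on these data alone, is whether the same groups on another carbon of the phenyl ring, or changes to the shared core, would read the same way in this assay.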